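This account rests on a few compounds, and the source may have more. Where it says the series, first, only, none or still open, it means among the compounds named here.

Compound 2 `COc1ccc(N(C)c2nc(C)nc3ccccc23)cc1` gives 3 nM in a functional assay on A549 cells (Homo sapiens) for inhibition, read by MTT assay, with a stated time of 48 h; a higher number here means a weaker inhibitor, a lower number a stronger inhibitor. Compound 1 `COc1ccc(N(C)c2nc(C)nc3ccccc23)cc1C(=O)OCCC[Se]C#N` gives 250 nM, while compound 3 `COc1ccc(N(C)c2nc(C)nc3ccccc23)cc1[Se]C#N` gives 49 nM, the second highest of the three numbers: nearest to it is a 5.1-fold lower number from compound 1 to compound 3 (0.71 log units; beyond the scatter), furthest is a 16-fold higher number from compound 2 to compound 3 (1.21 log units; beyond the scatter). Compound 4 `COc1ccc(N(C)c2nc(C)nc3ccccc23)cc1[Se]C` differs from compound 3 by methyl in place of cyano on a selenium. Among the measured compounds shown here, no measured step changes the group on selenium itself; the steps that bear on it are a 16-fold higher number from compound 2 to compound 3 (1.21 log units; beyond the scatter), a large rise where compound 2 carries hydrogen, and a 5.1-fold lower number from compound 1 to compound 3 (0.71 log units; beyond the scatter), a modest fall from the larger group of compound 1. Selenium stays in place in compound 4. Only a modest shift is expected, its direction uncertain. Compound 4 is therefore estimated at 30 nM, within 8 nM to 120 nM, a step of a 1.6-fold lower number from compound 3 to compound 4 (0.21 log units; within the scatter).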

Compound 4, half-maximal inhibitory concentration: 11 nM
Compound 4: the middle estimate sits 2.7-fold (0.44 log units) above what was measured, within the range that was stated.
By their numbers in this assay, from the lowest: compound 2; then compound 4; then compound 3; then compound 1.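

Changing only the group on selenium moves the number, so this position responds to what is attached to selenium and not only to selenium's presence: methyl in place of cyano gives (a 4.5-fold lower number from compound 3 to compound 4 (0.65 log units; beyond the scatter)). The methyl compound still sits short of the parent bearing hydrogen (a 3.7-fold higher number from compound 2 to compound 4 (0.56 log units; beyond the scatter)), yet it is well ahead of the larger ester group (a 23-fold lower number from compound 1 to compound 4 (1.36 log units; beyond the scatter)). Nothing available explains these shifts. The compounds shown leave open how a longer chain, such as ethyl, or a phenyl ring on selenium would read. They also leave open whether sulfur in place of selenium would keep the methyl compound's number.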